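The source may hold more compounds than are shown below. What is called first, only, known or untested is meant among the compounds shown, and "the series" means these compounds.

Three compounds have a number in an ADME assay on BV-2 cells (Mus musculus) for cytotoxicity, read by MTT assay, with a stated time of 48 h, tested at 5 uM; on this read-out higher numbers stand for a weaker effect at the one concentration tested and lower numbers for a stronger effect:

Compound 1, `O=C1COCCN1c1ccc(/N=C\c2c[nH]c3ccccc23)cc1`, gives 101%.
Compound 2, `Cc1ccc(S(=O)(=O)n2cc(/C=N\c3ccc(N4CCOCC4=O)cc3)c3ccccc32)cc1`, gives 89.1%.
Compound 3, `O=C1COCCN1c1ccc(/N=C\c2cn(C(=O)c3ccccc3)c3ccccc23)cc1`, gives 87.3%.

Compound 3 has the lowest of the three numbers in this assay. Its nearest neighbour is compound 2, and that gap, a number 1.8 percentage points lower from compound 2 to compound 3 (within the scatter), lies within the scatter; the gap to compound 1, a number 13.7 percentage points lower from compound 1 to compound 3 (beyond the scatter), lies beyond it.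

Compound 4, `O=C1COCCN1c1ccc(/N=C\c2cn(Cc3ccccc3)c3ccccc23)cc1`, differs from compound 3 in one place: benzyl in place of benzoyl on an aromatic nitrogen

Within the data shown here, three measured steps bear on this. Putting a large group on the aromatic nitrogen in place of hydrogen lowered the number modestly, a number 11.9 percentage points lower from compound 1 to compound 2 (beyond the scatter) and a number 13.7 percentage points lower from compound 1 to compound 3 (beyond the scatter). Exchanging one such large group for another, however, gave a number 1.8 percentage points lower from compound 2 to compound 3 (within the scatter), within the scatter. The step from compound 3 to compound 4 is again an exchange of one large group on that nitrogen for another, so no step beyond the scatter is expected in this assay, and the expected step is a number 0.3 percentage points lower from compound 3 to compound 4 (within the scatter). Compound 4 is therefore estimated at 87%, with a range from 77% to 97%.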

Compound 4, a percentage reported as activity, at one concentration (the size of the read-out at that concentration, not a potency): 84%
For compound 4 the middle estimate is 3 percentage points above the measured one, within the range that was stated.
By their numbers in this assay, from the lowest: compounds 4, 3 and 2 (each within the scatter of the next); then compound 1.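

In this assay the change to benzyl, which brings no carbonyl and no hydrogen-bond acceptor to the aromatic nitrogen, gives a number 3.3 percentage points lower from compound 3 to compound 4 (within the scatter) and a number 5.1 percentage points lower from compound 2 to compound 4 (within the scatter) in the same sentence of the record, so among these three large groups the link to the aromatic ring makes no readable difference at this position. Compared with hydrogen, benzyl gives a number 17 percentage points lower from compound 1 to compound 4 (beyond the scatter) and so joins the (4-methylphenyl)sulfonyl and benzoyl groups: all three large groups on this nitrogen now stand beyond the scatter from compound 1, with no exception among the compounds shown, and the lower number does not depend on the carbonyl of benzoyl. Nothing measured here accounts for this shift, and its cause remains unknown.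

The compounds shown leave open whether a small methyl on this nitrogen would already move the number away from that of compound 1, or whether only a group as large as benzyl does so. They also leave open what a longer chain ending in an amine or a carboxylic acid would do at this position, and how any of these compounds would behave at other concentrations.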